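One aromatic swap in a low-inhibition series

The source may report more compounds than this note shows. Statements on the series, on what has been measured and on what is new or still open speak of the compounds shown alone.

Compound 1 `Cc1cc(=O)c2c(O)cc(OC/C=C/c3ccccc3)c([C@H]3CCN(C)C[C@H]3O)c2o1` gives 9%
Compound 2 `Cc1cc(=O)c2c(O)c(CN3CCCC3CO)c(O)c([C@H]3CCN(C)C[C@H]3O)c2o1` gives 19%
Compound 3 `Cc1oc2c([C@H]3CCN(C)C[C@H]3O)c(O)cc(O)c2c(=O)c1C(O)c1cccc(Cl)c1` gives 4%

All three compounds were measured in a functional assay on Caco-2 cells (Homo sapiens) for inhibition, read by MTT assay, with a stated time of 48 h, tested at 10 uM (a lower number here means less inhibition of growth, a higher number more inhibition of growth at the concentration tested), and all three numbers are low. Compound 3 gives 4% there, which lies within the scatter of compound 1 at 9% so these two cannot be told apart. Compound 2 at 19% stands higher than compound 3 by more than the scatter.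

Compound 4 `Cc1oc2c([C@H]3CCN(C)C[C@H]3O)c(O)cc(O)c2c(=O)c1C(O)c1csc([N+](=O)[O-])c1` has not been measured yet. It carries 5-nitrothiophen-3-yl in place of 3-chlorophenyl on a saturated chain carbon bound to an aromatic carbon and an oxygen on a saturated carbon. Going by the values given here, no two measured compounds differ in one place only, so the data offer no direct guide to the size of such a swap. Even compound 2 reaches only 19% in this assay and so a large jump seems unlikely. No step beyond the scatter is expected, and the estimated change is a number 4 percentage points higher from compound 3 to compound 4 (within the scatter) in this assay as a small one in either direction would be no surprise. For compound 4 the expected value is 8% with an estimated range from 0% to 20% (still to be tested).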

Compound 4, percent growth inhibition at one concentration: 3%
Beside the measured number, compound 4's estimate is 5 percentage points above it; measured number inside the range.
By their numbers in this assay, from the lowest: compounds 4, 3, 1 and 2 (each within the scatter of the next, the first and the last beyond it).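

Going by these compounds alone, compound 3 and compound 4 are the first pair here that differ in one place only, so this site can now be read directly: in this assay, putting 5-nitrothiophen-3-yl in place of 3-chlorophenyl on a saturated chain carbon bound to an aromatic carbon and an oxygen on a saturated carbon gives a number 1 percentage points lower from compound 3 to compound 4 (within the scatter). Within the data shown here, the two groups differ in ring size, in ring atoms and in their count of hydrogen-bond acceptors, yet this assay cannot tell them apart, and with numbers this low, it shows only that neither group gives more than weak growth inhibition at the concentration tested. No measurement shown here accounts for this result.

On these data alone, it remains open whether a group of a different kind on the same carbon, such as a primary amine, a carboxylic acid or a longer alkyl chain, would give a number that stands clear of the scatter. As far as these compounds go, the hydroxy group on that carbon is also kept in both compounds, so it is still unknown what replacing it with a methoxy group would do.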